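A Basic Side Chain in Place of an Aldehyde

A few compounds are considered here, and "the series" means these few. Any claim that something is new, unique, unknown or untested is made for them only; others in the source may bear on it.

Compound 1, `Cn1c(Cc2nn(C)c(=O)c3ccccc23)nnc1SCCCCCCCC(=O)Nc1ccc(Cl)cc1Cl`, gives 2200 nM in an assay on 32D cells for inhibition of interleukin-15 (Mus musculus), read by resazurin assay, with stated times of 30 min and 2.5 days, in the presence of a further agent that is not named here; a higher number here means a weaker inhibitor, a lower number a stronger inhibitor.
Compound 2, `Cn1c(Cc2nn(CCC=O)c(=O)c3ccccc23)nnc1SCC(=O)Nc1ccc(Cl)cc1Cl`, gives 30000 nM in this assay.

Among the measured compounds shown here, compound 2 holds the higher of the two measured numbers, and its only neighbour, compound 1, sits well below it, a gap beyond the scatter. Compound 3, `CN(C)CCCn1nc(Cc2nnc(SCC(=O)Nc3ccc(Cl)cc3Cl)n2C)c2ccccc2c1=O`, differs from compound 2 by (dimethylamino)methyl in place of formyl on a saturated chain carbon, two bonds along the chain from an aromatic nitrogen. For the measured compounds named here, no measured pair shows this change, so its effect rests on no measured step. The estimated step in this assay is a modest fall, a 2.0-fold lower number from compound 2 to compound 3 (0.30 log units; within the scatter), not surely beyond the scatter. Compound 3 is thus expected to give 15000 nM, in the range 4000 nM to 50000 nM.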

Compound 3, half-maximal inhibitory concentration: 18800 nM
Compound 3: middle estimate off by 1.3-fold (0.10 log units), on the low side, within the range that was stated.
By their numbers in this assay, from the lowest: compound 1; then compounds 3 and 2 (each within the scatter of the next).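

In this assay, (dimethylamino)methyl in place of formyl on a saturated chain carbon, two bonds along the chain from an aromatic nitrogen, gives a 1.6-fold lower number from compound 2 to compound 3 (0.20 log units; within the scatter). This first measured step at this place shows that exchanging the 2-formylethyl chain for the 3-(dimethylamino)propyl chain leaves the reading within the scatter. No evidence is available to account for this result. As far as these compounds go, whether a carboxylic acid, a primary amine or a longer chain at this place would shift the number beyond the scatter remains open.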